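Removing the Nitrile from the Aryl Triazole

The compounds below may be only part of what the source reports. "The series", "measured", "known", "first", "only" and "open" are said of these compounds alone.

Compound 1, `CC1(C)[C@H]2CC[C@]1(C)N(Cc1cn(-c3cccc(F)c3)nn1)C(=O)C2`, gives 430 nM in a functional assay on OVCAR-3 cells (Homo sapiens) for inhibition, read by MTT assay, with a stated time of 24 h; on this read-out lower numbers stand for stronger inhibition and higher numbers for weaker inhibition.
Compound 2, `CC1(C)[C@H]2CC[C@]1(C)N(Cc1cn(-c3ccccc3C#N)nn1)C(=O)C2`, gives 110 nM.
Compound 3, `COc1ccccc1-n1cc(CN2C(=O)C[C@@H]3CC[C@@]2(C)C3(C)C)nn1`, gives 140 nM.

Compound 2 is the starting point here. Of the three measured numbers it is the lowest, but compound 3 lies within the usual scatter of it, so the two cannot be told apart; both sit well below compound 1, as a 3.9-fold lower number from compound 1 to compound 2 (0.59 log units; beyond the scatter) and a 3.1-fold lower number from compound 1 to compound 3 (0.49 log units; beyond the scatter) show. The step of a 1.3-fold higher number from compound 2 to compound 3 (0.10 log units; within the scatter) adds that exchanging one group for the other at that ring carbon changes little.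

Compound 4, `CC1(C)[C@H]2CC[C@]1(C)N(Cc1cn(-c3ccccc3)nn1)C(=O)C2`, differs from compound 2 by hydrogen in place of cyano on an aromatic carbon. Within the data shown here, no measured step removes a group from that ring carbon outright; the measured steps only exchange 2-cyanophenyl, 2-methoxyphenyl and 3-fluorophenyl for one another. Among these three, the two compounds carrying a group on that ring carbon gave lower numbers than compound 1, but nothing measured says what a bare phenyl does. The step from compound 2 to compound 4 is therefore expected to be a modest rise, a 2.3-fold higher number from compound 2 to compound 4 (0.36 log units; beyond the scatter), with considerable uncertainty. Compound 4 is estimated at 250 nM. The expected range for compound 4 runs from 110 nM to 600 nM.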

Compound 4, half-maximal inhibitory concentration: 50 nM
Compound 4: the middle estimate sits 5.0-fold (0.70 log units) above what was measured, outside the stated range (below it).
By their numbers in this assay, from the lowest: compound 4; then compounds 2 and 3 (each within the scatter of the next); then compound 1.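

In this assay, the bare phenyl ring of compound 4 shows that the ring needs no added group for a low number: taking away the nitrile lowers the number further (a 2.2-fold lower number from compound 2 to compound 4 (0.34 log units; beyond the scatter)), and taking away the methoxy does the same (a 2.8-fold lower number from compound 3 to compound 4 (0.45 log units; beyond the scatter)). The earlier compounds shown here could only rank 2-cyanophenyl and 2-methoxyphenyl against 3-fluorophenyl, which made those two groups look favourable; set against hydrogen, each now goes with weaker inhibition, and 3-fluorophenyl shows the largest gap of the set (an 8.6-fold lower number from compound 1 to compound 4 (0.93 log units; beyond the scatter)). Among these four compounds, every added group on the phenyl ring therefore goes with a higher number than hydrogen, no compound goes against this, and nothing available here explains why.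

Still open is whether a group smaller than those shown, such as a methyl group or a single chlorine atom, or a different kind of group, such as an amine, would also raise the number on the ring carbon that carries the nitrile in compound 2. Also open, going by these compounds, is how much of the gap for compound 1 comes from the fluoro group itself and how much from where it sits, which a fluoro group on that same ring carbon would help to separate.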